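Chloro in place of hydrogen: cytotoxicity notes on the series

A few compounds are considered here, and "the series" means these few. Any claim that something is new, unique, unknown or untested is made for them only; others in the source may bear on it.

Measured compounds, with values in an ADME assay on MT4 cells (Homo sapiens) for cytotoxicity; on this read-out higher numbers stand for lower toxicity in this test and lower numbers for higher toxicity in this test:
- Compound 1, `Cc1cc(C)cc(S(=O)(=O)n2c(SCC(=O)Nc3ccccc3[N+](=O)[O-])nc3ccccc32)c1`: compound 1 gives >= 26000 nM, which is a limit of this assay and not a number.
- Compound 2, `Cc1cc(C)cc(S(=O)(=O)n2c(SCC(=O)Nc3ccccc3[N+](=O)[O-])nc3ccc(Cl)cc32)c1`: compound 2 gives > 235000 nM, which is a limit of this assay and not a number.
- Compound 3, `COC(=O)c1ccc(NC(=O)CSc2nc3ccccc3n2Cc2cc(C)cc(C)c2)c(Cl)c1`: compound 3 gives 191000 nM in this assay, the only plain number among the three.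

Compound 4, `COC(=O)c1ccc(NC(=O)CSc2nc3ccc(Cl)cc3n2Cc2cc(C)cc(C)c2)c(Cl)c1`, has not been measured in this assay.

The change from compound 1 to compound 2 is chloro in place of hydrogen on an aromatic carbon. Its size in this assay is a step that the two limits leave unreadable from compound 1 to compound 2, since both ends rest on limits: the limit of > 235000 nM in this assay, at which 1 of the 3 values shown sits, and (the limit of >= 26000 nM in this assay, at which 1 of the 3 values shown sits). Nothing about the direction or size of this step can be read from the pair.

The change from compound 3 to compound 4 is chloro in place of hydrogen on an aromatic carbon, the same change in the same place. How the core of compound 3 differs from the core of compound 1 is not broken down here.

For the measured compounds named here, for compound 4 the step from compound 3 is expected to be a 1.0-fold lower number from compound 3 to compound 4 (0.00 log units; within the scatter), because the only measured instance of this change, a step that the two limits leave unreadable from compound 1 to compound 2, gives no readable size and so offers no ground for expecting a shift in either direction. The estimate for compound 4 in this assay is 190000 nM, expected to fall between 80000 nM and 400000 nM, with a fair chance that this assay again returns only a limit.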

Compound 4, half-maximal cytotoxic concentration: 105000 nM
Compound 4: middle estimate off by 1.8-fold (0.26 log units), on the high side; measured number inside the range.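

In this assay, chloro in place of hydrogen on an aromatic carbon of the core of compound 3 gives a 1.8-fold lower number from compound 3 to compound 4 (0.26 log units; within the scatter), so on this core the change is not told apart from the usual scatter of repeated measurements. This single readable step does not show that the change carries from one core to another, since the same change on the core of compound 1 gives a step that cannot be read and there is nothing to set beside it; compound 2 gives only a limit of the assay, not a number: the limit of > 235000 nM in this assay, at which 1 of the 4 values shown sits. Compound 1 likewise gives only a limit of the assay, not a number: the limit of >= 26000 nM in this assay, at which 1 of the 4 values shown sits.

The compounds shown leave open whether plain numbers for compound 1 and compound 2 would give a step like the one on the core of compound 3, and so whether the two cores respond alike to chloro. They also leave open how another group on the same aromatic carbon, such as fluoro, methoxy or an amine, would read in this assay on either core.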